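The source may report more compounds than this note shows. Statements on the series, on what has been measured and on what is new or still open speak of the compounds shown alone.

Measured in a functional assay on U-251 cells (Homo sapiens) for antiproliferative activity, read by MTT assay, with a stated time of 24 h; a lower number here means a stronger inhibitor, a higher number a weaker inhibitor:
Compound 1 `COc1cc(OC)c(-c2coc3cc(OCC(=O)c4cccc(C(F)(F)F)c4)ccc3c2=O)cc1OC`: > 10000 nM (a limit of the assay)
Compound 2 `COc1cc(OC)c(-c2coc3cc(OCc4cccc(Cl)c4)ccc3c2=O)cc1OC`: > 10000 nM (a limit of the assay)

Neither entry is a true number. Compound 2 stands at > 10000 nM, which is only a limit. The whole set so far rests on (the limit of > 10000 nM in this assay, at which 2 of the 2 values shown sit).

The next compound, compound 3 `COc1cc(OC)c(-c2coc3cc(OCc4cccc(Br)c4)ccc3c2=O)cc1OC`, keeps the rest of compound 2 and changes a single substituent: bromo in place of chloro on an aromatic carbon. Bromo takes the place of chloro on an aromatic carbon, on a six-membered aromatic ring of carbon only, meta to a large group.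

Within the data shown here, the only measured step is a step that the two limits leave unreadable from compound 1 to compound 2. Among the measured compounds shown here, it joins two limits, so it offers no size to carry over, and no measured step swaps chloro for bromo. In this assay, no step beyond the scatter is therefore expected, and no direction can be named. This expectation rests on compound 2 at > 10000 nM, again a limit.

The estimated step is a step that the limit leaves unreadable from compound 2 to compound 3. For compound 3 the estimate is 12000 nM, with an expected range of 5000 nM to 30000 nM, and the assay will probably report only a limit again.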

Compound 3, half-maximal inhibitory concentration: > 10000 nM
Compound 3: no number, only a limit (the forecaster's own chance of this, stated with the estimate: 75%); the middle value does not contradict the limit.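

In this assay compound 3 gives > 10000 nM, which is a limit of the assay and not a true number. No step among compound 1, compound 2 and compound 3 can be read, since all three rest on the same limit: the limit of > 10000 nM in this assay, at which 3 of the 3 values shown sit.

The compounds shown leave open how strong each of the three really is, and whether bromo in place of chloro changes the activity at all.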